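Arylamino in place of chlorobenzyl on the shared core

This account rests on a few compounds, and the source may have more. Where it says the series, first, only, none or still open, it means among the compounds named here.

Compound 1 `Cc1cc(Cc2cccc(Cl)c2)c(=O)n(CC(=O)Nc2ccc(Br)cc2)n1` is read in a functional assay on HL-60 cells (Homo sapiens), read by calcium flux; a lower number here means that less compound is needed, a higher number that more compound is needed for the effect. Here compound 1 gives only a limit, > 50000 nM. Compound 2 `Cc1cc(Cc2cccc(Cl)c2)c(=O)n(CC(=O)Nc2ccc(I)cc2)n1` likewise gives only a limit, > 50000 nM. Compound 3 `CC1=NN(CC(=O)Nc2ccc(I)cc2)C(=O)CC1` also gives only a limit, > 50000 nM. The step that the two limits leave unreadable from compound 1 to compound 2 is therefore unreadable, and the limit of > 50000 nM in this assay, at which 3 of the 3 values shown sit, sums up everything measured so far. Compound 4 `COc1ccc(Nc2cc(C)nn(CC(=O)Nc3ccc(Br)cc3)c2=O)cc1` differs from compound 1 by (4-methoxyphenyl)amino in place of 3-chlorobenzyl on an aromatic carbon, the (4-methoxyphenyl)amino sitting on an aromatic carbon of the six-membered aromatic ring with 2 nitrogen, opposite the ring nitrogen. Within the data shown here, no measured step touches this place or this kind of change, so neither direction nor size can be read from the series. With compound 1 at a limit, compound 4 is expected near 50000 nM, between 5000 nM and 200000 nM, most likely again as a limit. The step of a number no higher from compound 1 to compound 4 (the limit leaves the size open) is thus estimated to stay inside what these values can show.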

Compound 4, half-maximal effective concentration: > 50000 nM
Compound 4: a limit, no number; the forecaster's own chance of this, stated with the estimate: 70%; the middle value lies on the limit itself.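

Among these compounds, compound 1 and compound 4 both give only a limit, so no step between them can be read. The compounds shown leave open what concentration of any of them would give an effect in this assay.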